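Swapping an Ethynyl Chain End for a Hydroxylated Group

A few compounds are considered here, and "the series" means these few. Any claim that something is new, unique, unknown or untested is made for them only; others in the source may bear on it.

Measured in an assay on isolated protein for binding affinity to leukotriene B4 receptor 1 (Homo sapiens), tested at 1 uM; a higher number here means more inhibition at the concentration tested (going by the name of the read-out), a lower number less inhibition:
compound 1, `C=CCc1cc(C(C)=O)c(O)cc1OCCCCC#N`, gives 57%
compound 2, `C=CCc1cc(C(C)=O)c(O)cc1OCCCCCCCC#N`, gives 52%
compound 3, `C#CCCCCOc1cc(O)c(C(C)=O)cc1CC=C`, gives 29%

Compound 3 stands lowest of the three in this assay: a number 28 percentage points lower from compound 1 to compound 3 (beyond the scatter) and a number 23 percentage points lower from compound 2 to compound 3 (beyond the scatter), whereas a number 5 percentage points lower from compound 1 to compound 2 (within the scatter). Compound 4, `C=CCc1cc(C(C)=O)c(O)cc1OCCCCCC(C)(C)O`, has not yet been measured; it differs from compound 3 by 2-hydroxy-2-methylpropyl in place of ethynyl on a saturated chain carbon, four bonds along the chain from an oxygen on an aromatic ring. For the measured compounds named here, no measured step exchanges the ethynyl for a group of this kind, so the expectation rests only on the two steps reaching compound 3, which show the ethynyl end giving less inhibition than either nitrile-ended chain. A modest step upward is therefore expected, a number 16 percentage points higher from compound 3 to compound 4 (beyond the scatter), and compound 4 is estimated at 45%, within 25% to 65%.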

Compound 4, a percentage reported as inhibition, at one concentration (the size of the read-out at that concentration, not a potency): 60%
Compound 4: the middle estimate sits 15 percentage points below what was measured, within the range that was stated.
By their numbers in this assay, from the lowest: compound 3; then compounds 2, 1 and 4 (each within the scatter of the next).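

In (this assay) the 2-hydroxy-2-methylpropyl end clearly separates from the ethynyl end (a number 31 percentage points higher from compound 3 to compound 4 (beyond the scatter)), showing that this chain position accepts a hydroxylated end as well as a nitrile. Against the nitrile-ended chains the change cannot be told apart (a number 8 percentage points higher from compound 2 to compound 4 (within the scatter); a number 3 percentage points higher from compound 1 to compound 4 (within the scatter)). Nothing available explains why the ethynyl end stands apart from the other three. The compounds shown leave open how an amine or a carboxylic acid at this chain end would read, and whether a longer chain carrying the same hydroxylated end would hold this level.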